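The source may hold more compounds than are shown below. What is called first, only, known or untested is meant among the compounds shown, and "the series" means these compounds.

Working notes on compound 1 (`COC1=C(C)C(=O)/C(=C(O)/C=C/c2ccc(OC)cc2)C(=O)C1(C)C`), compound 2 (`COC1=C(C)C(=O)/C(=C(O)/C=C/c2ccc(C)cc2)C(=O)C1(C)C`) and compound 3 (`CCc1ccc(/C=C/C(O)=C2/C(=O)C(C)=C(OC)C(C)(C)C2=O)cc1`), which share one core.

In a functional assay on KB cells (Homo sapiens) for cytotoxicity (on this read-out lower numbers stand for an effect already at smaller amounts and higher numbers for an effect only at larger amounts of compound), compound 1 gives 3.6 ug/mL, and compound 2 gives 3.9 ug/mL. Among the compounds with values here, compound 2 is the only measured neighbour of compound 1, and the two cannot be ranked. The measured step is a 1.1-fold higher number from compound 1 to compound 2 (0.03 log units; within the scatter).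

Compound 3 carries ethyl in place of methoxy on an aromatic carbon, para to a large group, so 4-methoxyphenyl becomes 4-ethylphenyl: ethyl in place of methoxy on an aromatic carbon. Within the data shown here, the only measured step that bears on this is the one with methyl in place of methoxy on an aromatic carbon, and it is an indirect guide. Among the measured compounds shown here, no compound with ethyl has a number yet, so the data give no direct reading for that group.

On the evidence of compound 2, with its step of a 1.1-fold higher number from compound 1 to compound 2 (0.03 log units; within the scatter), no change beyond the scatter is expected in this assay, and no direction can be favoured. The estimate amounts to a 1.1-fold higher number from compound 1 to compound 3 (0.02 log units; within the scatter), which is expected to stay within the scatter. For compound 3 the estimated value is 3.8 ug/mL, with an expected range of 2 ug/mL to 7 ug/mL.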

Compound 3, concentration for half-maximal effect: 6.9 ug/mL
For compound 3 the middle estimate is 1.8-fold (0.26 log units) below the measured one; low and high end bracket the measured number.
By their numbers in this assay, from the lowest: compounds 1, 2 and 3 (each within the scatter of the next).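

Ethyl is now a third group read on this aromatic carbon, para to a large group, and in this assay replacing methoxy with ethyl gives a 1.9-fold higher number from compound 1 to compound 3 (0.28 log units; within the scatter), so a change that removes the oxygen and puts two carbons in its place stays inside the usual scatter. Extending the substituent by one carbon, with methyl in place of hydrogen on the saturated chain carbon bound to the aromatic carbon, gives a 1.8-fold higher number from compound 2 to compound 3 (0.25 log units; within the scatter), so methyl and ethyl cannot be separated here either, and compound 1, compound 2 and compound 3 remain unranked in this read-out. Nothing in the available data accounts for the size of either step.

The compounds shown leave open whether any group at this position moves the number beyond the scatter, since they cover only methoxy, methyl and ethyl and say nothing about an amine, a carboxylic acid, a longer chain such as butyl, or plain hydrogen. They also leave open whether the same indifference to the substituent holds on any cell type other than KB cells.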